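Benzyl amide step up from the low end

This account rests on a few compounds, and the source may have more. Where it says the series, first, only, none or still open, it means among the compounds named here.

In an ADME assay on HepG2 2.2.15 cells (Homo sapiens) for cytotoxicity, read by MTT assay, with stated times of 48 h and 9 days (a higher number here means that more compound is tolerated, a lower number that less compound is tolerated), compound 3 `COc1ccc2c(=O)c(/C=C/C(=O)Nc3ccccc3C)coc2c1` gives 59700 nM as the lowest of three numbers, under compound 2 `COc1ccc2c(=O)c(/C=C/C(=O)NCc3ccc(C)cc3)coc2c1` at 257000 nM and compound 1 `COc1ccc2c(=O)c(/C=C/C(=O)Nc3cc(C)ccc3C)coc2c1` at 1100000 nM in the same read-out. Within the data shown here, compound 4 `COc1ccc2c(=O)c(/C=C/C(=O)NCc3ccc(F)cc3F)coc2c1` is unmeasured and has 2,4-difluorobenzyl in place of 2-methylphenyl on an amide-type nitrogen as its one change. Among the measured compounds shown here, two measured steps bear on this: a 4.3-fold lower number from compound 2 to compound 3 (0.63 log units; beyond the scatter) on leaving a benzyl group, which compound 4 regains, and an 18-fold lower number from compound 1 to compound 3 (1.27 log units; beyond the scatter) for one methyl alone, which argues for a wide range. For the measured compounds named here, no compound with fluorine has been measured. A modest rise is expected, estimated as a 3.4-fold higher number from compound 3 to compound 4 (0.53 log units; beyond the scatter) overall. In this assay compound 4 is estimated at 200000 nM within a range of 60000 nM to 650000 nM for now.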

Compound 4, half-maximal cytotoxic concentration: 79300 nM
Beside the measured number, compound 4's estimate is 2.5-fold (0.40 log units) above it, and the stated range covers the measured number.
By their numbers in this assay, from the lowest: compounds 3 and 4 (each within the scatter of the next); then compound 2; then compound 1.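

In this assay a benzyl group on the amide-type nitrogen does not by itself set a compound apart from the 2-methylphenyl amide, as a 1.3-fold higher number from compound 3 to compound 4 (0.12 log units; within the scatter) shows for this change. What sits on the benzyl ring matters, with a 3.2-fold lower number from compound 2 to compound 4 (0.51 log units; beyond the scatter) for 2,4-difluorophenyl in place of 4-methylphenyl, while a 14-fold lower number from compound 1 to compound 4 (1.14 log units; beyond the scatter) keeps the 2,5-dimethylphenyl amide well apart. Nothing measured accounts for these steps. Open, on these data alone, is whether the step within the benzyl amides follows the two fluorines, the lost methyl or both. Also open, as far as these compounds go, is how an unsubstituted benzyl or a 2-phenylethyl chain on this nitrogen would read.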